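This account rests on a few compounds, and the source may have more. Where it says the series, first, only, none or still open, it means among the compounds named here.

Among the compounds with values here, compound 1 `COc1cc(NC(=O)Nc2cc(Nc3ccc(C(C)(C)C)cc3)ncn2)cc(OC)c1` is one of two compounds measured in a functional assay on NCI-H1581 cells (Homo sapiens) for inhibition, read by MTT assay, with a stated time of 48 h, tested at 10 uM (a higher number here means more inhibition at the concentration tested (going by the name of the read-out), a lower number less inhibition), where compound 1 gives 38.7%. Compound 2 `COc1cc(Br)ccc1Nc1cc(NC(=O)Nc2c(Cl)cccc2Cl)ncn1` gives 47.3%, a number within the usual scatter of that of compound 1, so the two cannot be told apart on these numbers. Compound 3 `CCc1cccc(Nc2cc(NC(=O)Nc3cc(OC)cc(OC)c3)ncn2)c1` differs from compound 1 in one place: 3-ethylphenyl in place of 4-(tert-butyl)phenyl on a nitrogen on an aromatic ring. Within the data shown here, no measured pair shows what such a change does, so the step is expected to stay within the scatter, with no clear direction. The expected step is a number 0.7 percentage points lower from compound 1 to compound 3 (within the scatter). Compound 3 is therefore estimated at 38%, within a range from 20% to 56%.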

Compound 3, a percentage reported as inhibition, at one concentration (the size of the read-out at that concentration, not a potency): 27.7%
Compound 3: the middle estimate sits 10.3 percentage points above what was measured; measured number inside the range.
By their numbers in this assay, from the lowest: compound 3; then compounds 1 and 2 (each within the scatter of the next).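

In this assay, 3-ethylphenyl in place of 4-(tert-butyl)phenyl gives a number 11 percentage points lower from compound 1 to compound 3 (beyond the scatter), so the group on this nitrogen can change the read-out. The swap alters both the alkyl group and its place on the ring, and this single pair cannot separate those two changes. No available evidence explains the step. Still open, going by these compounds, is whether 4-ethylphenyl would behave like 3-ethylphenyl or like 4-(tert-butyl)phenyl. On these data alone, it is also open how a phenyl ring carrying an amine or a carboxylic acid would read here.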